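A few compounds are considered here, and "the series" means these few. Any claim that something is new, unique, unknown or untested is made for them only; others in the source may bear on it.

Two compounds share one core and differ only in the group that sits on the amide-type nitrogen. Compound 1, `COc1cc(Cl)cc(-c2nn(-c3cccc(NC(=O)Nc4ccc(Cl)c(Cl)c4)c3)cc2-c2ccncc2)c1`, carries a 3,4-dichlorophenyl there; in a functional assay on UO-31 cells (Homo sapiens) for inhibition, read by sulforhodamine B assay, with a stated time of 48 h, tested at 0.1 uM (a lower number here means a stronger effect, a higher number a weaker effect of the compound at the concentration tested), compound 1 gives 500%. Compound 2, `COc1cc(Cl)cc(-c2nn(-c3cccc(NC(=O)Nc4cccc(C(F)(F)F)c4)c3)cc2-c2ccncc2)c1`, carries a 3-(trifluoromethyl)phenyl instead, and in this assay compound 2 gives 50%. Among the compounds with values here, that single exchange is the only measured step: a number 450 percentage points lower from compound 1 to compound 2 (beyond the scatter). Within the data shown here, on the numbers so far, compound 2 therefore stands lowest of the two, with compound 1 as its nearest neighbour well beyond the scatter above it.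

Compound 3, `COc1cc(Cl)cc(-c2nn(-c3cccc(NC(=O)c4cccc(C(F)(F)F)c4)c3)cc2-c2ccncc2)c1`, keeps everything in compound 2 except one part: 3-(trifluoromethyl)phenyl in place of (3-(trifluoromethyl)phenyl)amino on a carbonyl carbon. Among the measured compounds shown here, no measured step covers this kind of change; the one step known, from compound 1 to compound 2, swaps the group on the amide-type nitrogen and leaves the carbonyl untouched, so it is only a loose guide. With the 3-(trifluoromethyl)phenyl retained, the expected step in this assay is a number 20 percentage points higher from compound 2 to compound 3 (beyond the scatter), small and not clearly beyond the scatter. Compound 3 is therefore estimated at 70%, within a range from 25% to 180%.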

Compound 3, a percentage reported as activity, at one concentration (the size of the read-out at that concentration, not a potency): 88%
Estimate against measurement, compound 3: 18 percentage points below; low and high end bracket the measured number.
By their numbers in this assay, from the lowest: compound 2; then compound 3; then compound 1.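

Until now, only the aryl group at the end of the chain had changed; compound 3 changes the link itself, removing the amino nitrogen and the hydrogen-bond donor counted with it, so that the 3-(trifluoromethyl)phenyl sits directly on the carbonyl carbon. In this assay, this costs some effect, with a number 38 percentage points higher from compound 2 to compound 3 (beyond the scatter), yet the nitrogen is clearly not needed to stay far from the weak result of the dichlorinated compound, with a number 412 percentage points lower from compound 1 to compound 3 (beyond the scatter). No measurement available here explains the size of either step.

The compounds shown leave open whether a methylene group or an oxygen atom on that carbonyl carbon, in place of the amino nitrogen, would keep the effect of compound 2 or fall to that of compound 3. On these data alone, it also remains open whether a 3,4-dichlorophenyl placed directly on the carbonyl carbon would respond as the 3-(trifluoromethyl)phenyl does, and, with readings at only one concentration, whether these differences between a stronger and a weaker effect would hold at other concentrations.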